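Lengthening the benzyl amide chain to 3-phenylpropyl

The source may hold more compounds than are shown below. What is called first, only, known or untested is meant among the compounds shown, and "the series" means these compounds.

Compound 1 `C=CCN(CC=C)C(=O)c1cccc(C2SCC(=O)N2c2ccccc2OC)c1`: > 50000 nM (a limit of the assay, not a number)
Compound 2 `COc1ccccc1N1C(=O)CSC1c1cccc(C(=O)NCc2ccccc2)c1`: 5060 nM

Within the data shown here, in a functional assay on A549 cells (Homo sapiens) for antiproliferative activity, read by sulforhodamine B assay, with a stated time of 48 h (on this read-out lower numbers stand for stronger inhibition and higher numbers for weaker inhibition), compound 2 gives 5060 nM, the only actual number so far. Compound 1 reads > 50000 nM in this assay, which is a limit of the assay and not a number.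

Compound 3 `COc1ccccc1N1C(=O)CSC1c1cccc(C(=O)NCCCc2ccccc2)c1` is still to be measured. It keeps the core of compound 2 and differs in one place: phenethyl in place of phenyl on a saturated chain carbon bound to an amide-type nitrogen. This is phenethyl in place of phenyl on a saturated chain carbon bound to an amide-type nitrogen, which turns benzyl into 3-phenylpropyl.

Among the measured compounds shown here, only one measured step bears on this change: an at least 9.8-fold lower number from compound 1 to compound 2 (0.99 log units; beyond the scatter). One end of that step rests on (the limit of > 50000 nM in this assay, at which 1 of the 2 values shown sits). For the measured compounds named here, it shows that the group on this amide can shift the number in this assay, but it swapped diallylamino for benzylamino, and no measured step lengthens the chain. A step of similar size is therefore not expected here, and the likeliest outcome is none beyond the scatter. The expected step is a 1.1-fold lower number from compound 2 to compound 3 (0.05 log units; within the scatter). For compound 3 the estimate is 4500 nM, with an expected range of 1500 nM to 15000 nM.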

Compound 3, half-maximal inhibitory concentration: 31600 nM
Estimate against measurement, compound 3: 7.0-fold (0.85 log units) below; measured number outside the range, above it.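

The length of the chain on this amide matters by itself, and not only the kind of group that carries the phenyl ring. In this assay, going from benzyl to 3-phenylpropyl gives a 6.2-fold higher number from compound 2 to compound 3 (0.80 log units; beyond the scatter), so the benefit seen with benzylamino does not carry over to the longer (3-phenylpropyl)amino, even though the phenyl ring is kept. Against the diallylamino amide the reading is an at least 1.5-fold lower number from compound 1 to compound 3 (0.19 log units; that floor lies within the scatter), and since that floor lies within the scatter, it cannot be said how far compound 3 stands from compound 1, whose > 50000 nM is a limit of the assay and not a number: the limit of > 50000 nM in this assay, at which 1 of the 3 values shown sits.

The compounds shown leave open how the number behaves at other chain lengths, whether a 2-phenylethyl amide reads closer to compound 2 or to compound 3, and whether a longer chain such as 4-phenylbutyl raises it further. They also leave open whether a fluorine or a methoxy on the phenyl ring of the benzyl amide, or an amine at the end of the chain, would move the number in either direction.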